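The source may hold more compounds than are shown below. What is called first, only, known or untested is meant among the compounds shown, and "the series" means these compounds.

Compound 1 `Cc1nc(N2CCC(N3CCOC3=O)CC2)nc2ccc(NC(=O)/C=C/c3ccc(OC(F)(F)F)cc3)cc12` was run in an ADME assay on microsomes from liver (Mus musculus) for metabolic stability, with a stated time of 30 min; on this read-out higher numbers stand for a more stable compound and lower numbers for a less stable compound. In this assay compound 1 gives 74%. Going by the values given here, the only other measured compound, compound 2 `C/C(=C\C(=O)Nc1ccc2nc(N3CCC(N4CCCC4=O)CC3)nc(C)c2c1)c1ccc(OC(F)(F)F)cc1`, is built on the same core but differs from compound 1 in more than one place, so no single step connects the two. In this assay compound 2 gives 86%. Of the two numbers in hand, compound 1 is the lower one, and the gap up to compound 2 is larger than the usual scatter of this kind of measurement.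

Compound 3 `Cc1nc(N2CCC(N3CCNC3=O)CC2)nc2ccc(NC(=O)/C=C/c3ccc(OC(F)(F)F)cc3)cc12` has not yet been measured. It differs from compound 1 in exactly one place: 2-oxoimidazolidin-1-yl in place of 2-oxo-1,3-oxazolidin-3-yl on a saturated ring carbon. Among the compounds with values here, no measured pair in this small set shows this particular exchange, so there is no directly comparable step to lean on. The change is small in size, and on that basis the step from compound 1 to compound 3 is expected to be a number 2 percentage points lower from compound 1 to compound 3 (within the scatter), which is no change beyond the scatter. Compound 3 is therefore estimated to give about 72% in this assay, with a plausible range from 55% to 88%.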

Compound 3, percent of the compound remaining: 89%
For compound 3 the middle estimate is 17 percentage points below the measured one, and the stated range ends below it.
By their numbers in this assay, from the lowest: compound 1; then compounds 2 and 3 (each within the scatter of the next).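

Replacing 2-oxo-1,3-oxazolidin-3-yl with 2-oxoimidazolidin-1-yl on the saturated ring carbon gives, in this assay, a number 15 percentage points higher from compound 1 to compound 3 (beyond the scatter), which shows that this position responds to a change that leaves the size of the five-membered ring untouched. The two groups have the same number of heavy atoms, but the entering group has a nitrogen where the leaving group has an oxygen, and it also has a hydrogen-bond donor that the leaving group lacks, so a swap of one ring atom is enough to move the read-out beyond the usual scatter. Nothing available here explains why this exchange gives a higher number.

This single step cannot separate the effect of the added donor from that of the changed ring atom, and it cannot say whether the same exchange would have a similar effect on another compound in the series. It also leaves open how an open-chain urea, an amine or a carboxylic acid on the same saturated ring carbon would compare with 2-oxoimidazolidin-1-yl.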